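Adding one hydroxy to compound 2

This account rests on a few compounds, and the source may have more. Where it says the series, first, only, none or still open, it means among the compounds named here.

Compound 1 `Oc1ccc(-c2ccc(-c3ccc(-c4nc5ccccc5[nH]4)cc3)cc2)cc1`: 33100 nM
Compound 2 `CN(C)c1ccc(-c2ccc(-c3ccc(-c4nc5ccccc5[nH]4)cc3)cc2)cc1`: 30100 nM

For the measured compounds named here, in a functional assay on A549 cells (Homo sapiens) for inhibition, read by sulforhodamine B assay (a lower number here means a stronger inhibitor of growth, a higher number a weaker inhibitor of growth), compound 2 stands level with compound 1, the only other compound measured so far. Compound 3 `CN(C)c1ccc(-c2ccc(-c3ccc(-c4nc5c(O)cccc5[nH]4)cc3)cc2)cc1` differs from compound 2 by hydroxy in place of hydrogen on an aromatic carbon. Going by the values given here, the only measured step, a 1.1-fold lower number from compound 1 to compound 2 (0.04 log units; within the scatter), swaps dimethylamino for hydroxy at a different place, so it offers only weak guidance here. Among the compounds with values here, no measured step tests this new place, so no change beyond the scatter is expected, though with wide uncertainty. The expected step is a 1.2-fold lower number from compound 2 to compound 3 (0.08 log units; within the scatter). Compound 3 is expected at about 25000 nM, with an estimated range of 8000 nM to 60000 nM.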

Compound 3, concentration for 50% growth inhibition: 7100 nM
The estimate for compound 3 lay 3.5-fold (0.55 log units) above the measured number, and the stated range ends above it.
By their numbers in this assay, from the lowest: compound 3; then compounds 2 and 1 (each within the scatter of the next).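

In this assay, the change to 4-hydroxy-1H-benzimidazol-2-yl gives a 4.2-fold lower number from compound 2 to compound 3 (0.63 log units; beyond the scatter). For the compounds shown here, this is the first step to pass the scatter, so this aromatic carbon, unlike the place of the earlier swap, can shift the number. No measurement shown bears on the reason for this step.

Going by these compounds, it remains open whether hydroxy itself matters here, or whether methoxy or an amine on the same carbon would give a similar step. It is also unknown whether hydroxy on the other carbons of this ring would do the same.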